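Working notes on a cytotoxicity series: a chloro step

The compounds below may be only part of what the source reports. "The series", "measured", "known", "first", "only" and "open" are said of these compounds alone.

Measured so far:
compound 1 `COc1cccc(/C=C2\CCC/C(=C\c3cc(OC)c(OC)c(OC)c3)C2=O)c1OC` — 2500 nM
compound 2 `COc1cccc(/C=C2\CCC/C(=C\c3ccc(O)c(O)c3)C2=O)c1OC` — 6300 nM
compound 3 `COc1ccc(/C=C2\CCC/C(=C\c3ccc(Cl)cc3)C2=O)cc1OC` — 5900 nM

All three numbers come from a functional assay on SW-620 cells (Homo sapiens) for cytotoxicity, read by MTT assay, with a stated time of 72 h; on this read-out lower numbers stand for stronger inhibition and higher numbers for weaker inhibition. Compound 3 stands second highest of the three. Its nearest neighbour is compound 2, whose number is only slightly higher, a gap that lies within the scatter of this assay, so no order between compound 2 and compound 3 can be stated. Compound 1 is furthest away, with a lower number than compound 3 by a gap beyond the scatter.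

The next compound, compound 4 `COc1ccc(/C=C2\CCC/C(=C\c3ccc(Cl)cc3Cl)C2=O)cc1OC`, keeps the core of compound 3 and differs from it in one place:
chloro in place of hydrogen on an aromatic carbon

Within the data shown here, no step between two measured compounds is known, so nothing here shows how this kind of change moves the number. With the values of compound 1, compound 2 and compound 3 lying close together, the expectation for compound 4 is a step of no more than modest size, most likely within the scatter, in either direction. The estimated step from compound 3 to compound 4 is a 1.3-fold lower number from compound 3 to compound 4 (0.12 log units; within the scatter). On that basis compound 4 is expected to give about 4500 nM, with a range from 1500 nM to 13000 nM.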

Compound 4, half-maximal inhibitory concentration: 10300 nM
Beside the measured number, compound 4's estimate is 2.3-fold (0.36 log units) below it; low and high end bracket the measured number.
By their numbers in this assay, from the lowest: compound 1; then compounds 3, 2 and 4 (each within the scatter of the next).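

In this assay the series now has its first readable step between two compounds that differ in one place: chloro in place of hydrogen on an aromatic carbon, 4-chlorophenyl to 2,4-dichlorophenyl, gives a 1.7-fold higher number from compound 3 to compound 4 (0.24 log units; within the scatter) and so stays within the scatter. At this place, ortho to a large group and meta to the existing chloro group, the second chloro therefore brings no change that can be separated from repeat-to-repeat variation, and the two compounds cannot be ranked against each other. Nothing available bears on why the step is this size.

Going by these compounds, this single pair gives a size for one substitution on one core and supports no trend for the position, so it stays open whether an amine, a carboxylic acid or a longer chain such as an ethyl ether on the same aromatic carbon would move the number beyond the scatter. On these data alone, it also stays open whether the same chloro step would read alike on the aromatic ends carried by compound 1 or compound 2.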